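Changing the Aryl Group on a Shared Core

This account rests on a few compounds, and the source may have more. Where it says the series, first, only, none or still open, it means among the compounds named here.

Of the compounds shown here, three built on one shared core have been tested in a functional assay on MV4-11 cells (Homo sapiens) for inhibition, with a stated time of 120 h, tested at 10 uM; on this read-out higher numbers stand for more inhibition at the one concentration tested (going by the name of the read-out) and lower numbers for less inhibition. Compound 1 `Cc1n[nH]c2ccc(-c3nc4cnc(N5CCN(C)CC5)cn4c3Nc3ccc(F)cc3)cc12` gives 0% in this assay. Compound 2 `Cc1n[nH]c2ccc(-c3nc4cnc(N5CCN(C)CC5)cn4c3Nc3cccc(Cl)c3)cc12` gives 0% in this assay. Compound 3 `Cc1ccc(C)c(Nc2c(-c3ccc4[nH]nc(C)c4c3)nc3cnc(N4CCN(C)CC4)cn23)c1` gives 0% in this assay. The three differ from one another only in the ring that sits on a nitrogen on an aromatic ring of the shared core: 4-fluorophenyl in compound 1, 3-chlorophenyl in compound 2, 2,5-dimethylphenyl in compound 3. None of these swaps moved the read-out: no change at the digits printed from compound 1 to compound 2 (within the scatter), no change at the digits printed from compound 1 to compound 3 (within the scatter) and no change at the digits printed from compound 2 to compound 3 (within the scatter). Compound 3 therefore stands level with compound 1 and compound 2, all at the bottom of the scale.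

Compound 4 `Cc1n[nH]c2ccc(-c3nc4cnc(N5CCN(C)CC5)cn4c3Nc3ccc(F)c(Cl)c3)cc12` carries yet another ring in that position. Relative to compound 3 the change is 3-chloro-4-fluorophenyl in place of 2,5-dimethylphenyl on a nitrogen on an aromatic ring. Among the measured compounds shown here, every measured step so far has been a swap of one ring for another at this same nitrogen, and each stayed within the scatter, so the step to compound 4 is expected to be flat as well: no change at the digits printed from compound 3 to compound 4 (within the scatter). Compound 4 is thus estimated to give 0% in this assay, with a range from -10% to 12%.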

Compound 4, a percentage reported as inhibition, at one concentration (the size of the read-out at that concentration, not a potency): 84.1%
Estimate against measurement, compound 4: 84.1 percentage points below, and the stated range ends below it.
By their numbers in this assay, from the lowest: compounds 1, 2 and 3 (each within the scatter of the next); then compound 4.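

In this assay this nitrogen proves not to be a position where every ring swap goes unnoticed: replacing 2,5-dimethylphenyl with 3-chloro-4-fluorophenyl gives a number 84.1 percentage points higher from compound 3 to compound 4 (beyond the scatter), although the two groups have the same count of heavy atoms. The single-atom changes are more telling, as adding fluoro to the 3-chlorophenyl ring gives a number 84.1 percentage points higher from compound 2 to compound 4 (beyond the scatter) and adding chloro to the 4-fluorophenyl ring gives a number 84.1 percentage points higher from compound 1 to compound 4 (beyond the scatter), so in this small set the ring with one halogen does nothing measurable, while the ring with both gives strong inhibition. Nothing available accounts for this dependence on having both atoms on the ring.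

The compounds shown leave open whether both substituents must be halogens, a question that a ring with a methyl group in place of the chloro, or a nitrile in place of the fluoro, could address. Also open, as far as these compounds go, is how the 3-chloro-4-fluorophenyl compound would behave at lower concentrations, as a single concentration gives its inhibition but not its potency.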